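A few compounds are considered here, and "the series" means these few. Any claim that something is new, unique, unknown or untested is made for them only; others in the source may bear on it.

Three compounds share one core and differ only in the aromatic ring attached to the carbon with a double bond to nitrogen. Compound 1 `O=C(CSc1nnc(-c2ccncc2)o1)N/N=C/c1ccccc1` carries an unsubstituted ring there; in a functional assay on SW 1116 cells (Homo sapiens) for cytotoxicity, read by MTT assay, with a stated time of 48 h (a higher number here means a weaker inhibitor, a lower number a stronger inhibitor), compound 1 gives 16700 nM. Compound 2 `COc1cccc(/C=N/NC(=O)CSc2nnc(-c3ccncc3)o2)c1` carries a methoxy group on that ring, and in this assay compound 2 gives 16500 nM. Compound 3 `O=C(CSc1nnc(-c2ccncc2)o1)N/N=C/c1ccccc1F` carries a fluoro group, and in this assay compound 3 gives 21500 nM. Compound 3 stands alongside the other two: the steps of a 1.3-fold higher number from compound 1 to compound 3 (0.11 log units; within the scatter) and a 1.3-fold higher number from compound 2 to compound 3 (0.11 log units; within the scatter) are both within the scatter, as is a 1.0-fold lower number from compound 1 to compound 2 (0.01 log units; within the scatter).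

Compound 4 `COc1cc(/C=N/NC(=O)CSc2nnc(-c3ccncc3)o2)ccc1O` has not yet been measured. Its difference from compound 3 is 4-hydroxy-3-methoxyphenyl in place of 2-fluorophenyl on a carbon with a double bond to nitrogen. Among the measured compounds shown here, two measured steps bear on this: adding a methoxy group, a 1.0-fold lower number from compound 1 to compound 2 (0.01 log units; within the scatter), and adding a fluoro group, a 1.3-fold higher number from compound 1 to compound 3 (0.11 log units; within the scatter), neither of which moved the number beyond the scatter. For the measured compounds named here, the hydroxy group has no counterpart among the measured compounds. The expected step is therefore a 1.3-fold lower number from compound 3 to compound 4 (0.10 log units; within the scatter), meaning none beyond the scatter. Compound 4 is expected to give about 17000 nM in this assay, within a range from 8000 nM to 40000 nM.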

Compound 4, half-maximal inhibitory concentration: 3590 nM
The estimate for compound 4 lay 4.7-fold (0.68 log units) above the measured number; measured number outside the range, below it.
By their numbers in this assay, from the lowest: compound 4; then compounds 2, 1 and 3 (each within the scatter of the next).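

In this assay, among the compounds shown here, the aromatic ring on the carbon with a double bond to nitrogen proves able to shift the number: adding a hydroxy group to that ring gives a 4.6-fold lower number from compound 2 to compound 4 (0.66 log units; beyond the scatter), the plainest comparison, since only that one group changes. The steps of a 4.7-fold lower number from compound 1 to compound 4 (0.67 log units; beyond the scatter) and a 6.0-fold lower number from compound 3 to compound 4 (0.78 log units; beyond the scatter) confirm that compound 4 is the strongest of the four, with each of its steps beyond the scatter, whereas the methoxy and fluoro changes alone stayed within it. Nothing available explains why this change has such an effect.

Going by these compounds, it remains open whether the hydroxy group would give the same step without the methoxy group on the same ring. On these data alone, it is also open whether an amine or a carboxylic acid in its place would move the number in the same way.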